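The source may hold more compounds than are shown below. What is called first, only, known or untested is meant among the compounds shown, and "the series" means these compounds.

The compounds measured so far:

- compound 1, `CCOC(=O)C(=Cc1c(-c2ccccc2)[nH]c2ccccc12)C(=O)OCC`, gives 4200 nM in a functional assay on M14 cells (Homo sapiens) for inhibition, read by sulforhodamine B assay, with a stated time of 48 h; on this read-out lower numbers stand for stronger inhibition of growth and higher numbers for weaker inhibition of growth
- compound 2, `CC(=O)/C(=C\c1c(-c2ccccc2)[nH]c2ccccc12)S(=O)(=O)c1ccccc1`, gives 521 nM in this assay
- compound 3, `COc1ccc(-c2[nH]c3ccc(OC)cc3c2C=C(C#N)C#N)cc1`, gives 308 nM in this assay

All three share a core on which a chain with a double bond carries two electron-withdrawing groups, and they differ in what those groups are and in what sits on the core. Compound 2 stands second highest of the three numbers in this assay. Its nearest neighbour is compound 3, whose number lies within the usual scatter of repeated measurements, so the two cannot be told apart on these data. Compound 1 lies furthest away, with a higher number that is clearly beyond the scatter, meaning it inhibits growth more weakly than compound 2.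

The next compound, compound 4, `N#C/C(=C\c1c(-c2ccccc2)[nH]c2ccccc12)S(=O)(=O)c1ccccc1`, has not yet been measured in this assay. It differs from compound 2 in one place: cyano in place of acetyl on a double-bonded chain carbon bound to a double-bonded chain carbon and a sulfonyl sulfur. Within the data shown here, no measured pair in this set isolates this exact change, so there is no step to lean on directly. Compound 3 carries two cyano groups on its chain and gives a number within the scatter of compound 2, which points towards no step beyond the scatter. Compound 4 is therefore expected to give 400 nM in this assay, with a range from 150 nM to 1100 nM. The expected step is a 1.3-fold lower number from compound 2 to compound 4 (0.11 log units; within the scatter).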

Compound 4, concentration for 50% growth inhibition: 3800 nM
Compound 4: middle estimate off by 9.5-fold (0.98 log units), on the low side; measured number above the stated range.
By their numbers in this assay, from the lowest: compounds 3 and 2 (each within the scatter of the next); then compounds 4 and 1 (each within the scatter of the next).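

In this assay, replacing acetyl with cyano on a double-bonded chain carbon bound to a double-bonded chain carbon and a sulfonyl sulfur brings a 7.3-fold higher number from compound 2 to compound 4 (0.86 log units; beyond the scatter), so growth inhibition clearly weakens with this one change while the rest of the molecule stays the same. Among these compounds, this is the first comparison in the set that isolates a single place: compound 3 also carries cyano on its chain, but it differs from compound 2 in more than one place and could not show what this swap does alone. Acetyl and cyano each count one hydrogen-bond acceptor and no donors, so those counts do not separate the two groups, and nothing measured here explains the loss in activity.

From the compounds shown here alone, it remains open whether acetyl is unusually favourable at this position or cyano unusually poor, a question that a methyl ester, a primary amide or a longer ketone chain in the same place could help to settle. It is also unknown whether the same swap would have a similar effect with a methoxy group on the core or with a different group in place of the phenylsulfonyl.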